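The source may hold more compounds than are shown below. What is called first, only, known or untested is meant among the compounds shown, and "the series" means these compounds.

Compound 1 `S=C1NCCN1Cc1ccc(Cl)cc1`: 4300 nM
Compound 2 `S=C1NCCCN1Cc1ccccc1`: > 10000 nM (a limit of the assay, not a number)
Compound 3 `S=C1NCCCN1Cc1ccc(Cl)cc1`: 2400 nM

All three compounds were tested in a functional assay on B16 cells (Mus musculus) for inhibition, with a stated time of 72 h; on this read-out higher numbers stand for weaker inhibition and lower numbers for stronger inhibition. Compound 3 at 2400 nM has one of the two exact numbers, and it lies within the usual scatter of compound 1 at 4300 nM, so the two cannot be ranked.

Compound 4 `CC(C)c1ccc(CN2CCCNC2=S)cc1` keeps the rest of compound 3 and alters one group: isopropyl in place of chloro on an aromatic carbon. In short, isopropyl takes the place of chloro on an aromatic carbon. For the measured compounds named here, one measured step bears on this change: an at least 4.1-fold lower number from compound 2 to compound 3 (0.61 log units; beyond the scatter), where chloro replaced hydrogen on an aromatic carbon. Going by the values given here, that step lies beyond the scatter, but it compares a group with no group, and no isopropyl compound has been measured yet. Compound 4 still carries a group there, so only a small shift is expected, in no firmly known direction. The expected change is a 1.3-fold higher number from compound 3 to compound 4 (0.10 log units; within the scatter), which would not clearly exceed the scatter. Compound 4 is estimated at 3000 nM, with an expected range from 1000 nM to 9000 nM.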

Compound 4, half-maximal inhibitory concentration: 800 nM
Beside the measured number, compound 4's estimate is 3.8-fold (0.57 log units) above it; measured number below the stated range.
By their numbers in this assay, from the lowest: compound 4; then compounds 3 and 1 (each within the scatter of the next). At a limit, above all of these: compound 2.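

In this assay, the earlier step showed only that chloro on this aromatic carbon does better than hydrogen, and the new result adds that the choice of group counts too: a 3.0-fold lower number from compound 3 to compound 4 (0.48 log units; beyond the scatter). With hydrogen as the starting point, the isopropyl change gives an at least 12-fold lower number from compound 2 to compound 4 (1.09 log units; beyond the scatter). That step is only a bound, because compound 2 stands at a limit of the assay and not at a number: the limit of > 10000 nM in this assay, at which 1 of the 4 values shown sits.

The compounds shown carry only hydrogen, chloro or isopropyl at this place, so whether a tert-butyl group, a methoxy group or an amine there would give a lower or a higher number stays open. Isopropyl is also seen only on the core of compound 3, so its effect on the core of compound 1 remains unknown.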